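Thiourea chain variation on a chloroquinoline core

A few compounds are considered here, and "the series" means these few. Any claim that something is new, unique, unknown or untested is made for them only; others in the source may bear on it.

Measured compounds:
compound 1 `NCCNC(=S)Nc1ccnc2cc(Cl)ccc12`, 18000 nM in a functional assay on HeLa cells (Homo sapiens) for cytotoxicity, read by MTT assay, with a stated time of 7 h; on this read-out lower numbers stand for stronger inhibition and higher numbers for weaker inhibition
compound 2 `OCCNC(=S)Nc1ccnc2cc(Cl)ccc12`, > 50000 nM in this assay
compound 3 `CN(C)CCCNC(=S)Nc1ccnc2cc(Cl)ccc12`, 48500 nM in this assay

Among the numbers obtained, compound 3 has the highest; the nearest is compound 1, a step of a 2.7-fold higher number from compound 1 to compound 3 (0.43 log units; beyond the scatter). Compound 2 reached only the limit of the assay, (the limit of > 50000 nM in this assay, at which 1 of the 3 values shown sits). The step of an at least 2.7-fold higher number from compound 1 to compound 2 (0.44 log units; beyond the scatter) is therefore only a bound, and an at least 1.0-fold lower number from compound 2 to compound 3 (0.01 log units; that floor lies within the scatter) likewise rests on that limit.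

Compound 4 `CCN(CC)CCCNC(=S)Nc1ccnc2cc(Cl)ccc12` differs from compound 3 by diethylamino in place of dimethylamino on a saturated chain carbon, three bonds along the chain from an amide-type nitrogen. For the measured compounds named here, none of the measured steps alters the alkyl groups on the chain amine itself; the steps involving compound 1 concern exchange of the whole terminal group, not its size. Going by the values given here, with no step bearing directly on this change, no shift beyond the scatter is expected, and the estimated step is a 1.1-fold higher number from compound 3 to compound 4 (0.05 log units; within the scatter). For compound 4 the expected value in this assay is 55000 nM, within a range of 20000 nM to 150000 nM, with a real chance that only a limit is reported.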

Compound 4, half-maximal inhibitory concentration: 49200 nM
Estimate against measurement, compound 4: 1.1-fold (0.05 log units) above; low and high end bracket the measured number.
By their numbers in this assay, from the lowest: compound 1; then compounds 3 and 4 (each within the scatter of the next). At a limit, above all of these: compound 2.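

In this assay, for the compounds shown here, the first change to the alkyl groups on the chain amine itself, diethylamino in place of dimethylamino on a saturated chain carbon, three bonds along the chain from an amide-type nitrogen, gives a 1.0-fold higher number from compound 3 to compound 4 (0.01 log units; within the scatter). The gap to the chain with a free terminal amino group remains beyond the scatter with the larger amine in place (a 2.7-fold higher number from compound 1 to compound 4 (0.44 log units; beyond the scatter)), and it is modest. The value of compound 2 is a limit and not a number: the limit of > 50000 nM in this assay, at which 1 of the 4 values shown sits. The step of an at least 1.0-fold lower number from compound 2 to compound 4 (0.00 log units; that floor lies within the scatter) rests on that limit and cannot be read.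

Still open, going by these compounds, is whether the gap to compound 1 follows the terminal amine's substitution or the chain's length, a question that a free amine on the longer chain would address. Also open, on these data alone, is how a piperidine or a morpholine in place of diethylamino would read in this assay.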